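Removing a Methyl From an Aryl Ether: Expected Growth Inhibition

The source may hold more compounds than are shown below. What is called first, only, known or untested is meant among the compounds shown, and "the series" means these compounds.

Compound 1 `Cc1cc(O)cc(-c2nn(CC#N)cc2-c2ccnc(-c3ccc(Oc4ccccc4)cc3)c2)c1` gives 2990 nM in a functional assay on U-251 cells (Homo sapiens) for inhibition, read by sulforhodamine B assay, with a stated time of 48 h; a higher number here means a weaker inhibitor of growth, a lower number a stronger inhibitor of growth.
Compound 2 `COc1cc(C)cc(-c2nn(CC#N)cc2-c2ccnc(-c3ccc(N(C)C)cc3)c2)c1` gives 5860 nM in this assay.

Compound 2 carries the higher of the two numbers in this assay, but its nearest neighbour, compound 1, lies within the scatter of it, so no order between them is drawn. Compound 3 `Cc1cc(O)cc(-c2nn(CC#N)cc2-c2ccnc(-c3ccc(N(C)C)cc3)c2)c1` is not yet measured in this assay. It differs from compound 2 in one place: hydrogen in place of methyl on an oxygen on an aromatic ring. Going by the values given here, no measured pair shows this change on its own, so there is no step to lean on. The change is expected to be a 1.5-fold lower number from compound 2 to compound 3 (0.17 log units; within the scatter), nothing beyond the scatter. Compound 3 is therefore estimated at 4000 nM in this assay, with a range from 1500 nM to 11000 nM.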

Compound 3, concentration for total growth inhibition: 12900 nM
Compound 3: the middle estimate sits 3.2-fold (0.51 log units) below what was measured; measured number outside the range, above it.
By their numbers in this assay, from the lowest: compounds 1 and 2 (each within the scatter of the next); then compound 3.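

In this assay, the change from methoxy to hydroxy proves not to be neutral, and the hydrogen in place of methyl gives a weaker result ((a 2.2-fold higher number from compound 2 to compound 3 (0.34 log units; beyond the scatter))). With the hydroxy kept, dimethylamino in place of phenoxy also counts against growth inhibition ((a 4.3-fold higher number from compound 1 to compound 3 (0.63 log units; beyond the scatter))), so each of the two places moves the number beyond the scatter. Nothing measured here explains either step.

The compounds shown leave open whether methoxy to hydroxy moves the number the same way with phenoxy in place of dimethylamino. Going by these compounds, how an ethoxy or an amine would stand in place of the methoxy also remains open.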